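Exchanging the group on the sulfonyl sulfur of compound 3

A few compounds are considered here, and "the series" means these few. Any claim that something is new, unique, unknown or untested is made for them only; others in the source may bear on it.

- Compound 1 `COc1ccc(S(=O)(=O)NC(C2=CC(=O)c3c(O)ccc(O)c3C2=O)C(C)C)c(OC)c1`: 2750 nM
- Compound 2 `CC(C)C(NS(=O)(=O)c1ccc(Br)cc1)C1=CC(=O)c2c(O)ccc(O)c2C1=O`: 7650 nM
- Compound 3 `COc1ccc(S(=O)(=O)NC(C)C2=CC(=O)c3c(O)ccc(O)c3C2=O)c(OC)c1`: 19500 nM

In a functional assay on HeLa cells (Homo sapiens) for cytotoxicity, read by sulforhodamine B assay (on this read-out higher numbers stand for weaker inhibition and lower numbers for stronger inhibition), compound 3 has the highest number of the three measured compounds, at 19500 nM, which makes it the weakest inhibitor so far. The compound still to be measured is compound 4 `CC(NS(=O)(=O)c1ccc(Br)cc1)C1=CC(=O)c2c(O)ccc(O)c2C1=O`, where 4-bromophenyl takes the place of 2,4-dimethoxyphenyl on a sulfonyl sulfur: 4-bromophenyl in place of 2,4-dimethoxyphenyl on a sulfonyl sulfur.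

The same exchange has been measured once, on the isopropyl-bearing pair: a 2.8-fold higher number from compound 1 to compound 2 (0.44 log units; beyond the scatter). Going by the values given here, this is the closest guide, although one pair is thin evidence, and no measurement yet shows that the exchange behaves alike when the chain carries methyl. The other measured step, a 7.1-fold higher number from compound 1 to compound 3 (0.85 log units; beyond the scatter), concerns methyl in place of isopropyl. It does not touch the group on the sulfonyl sulfur.

A modest move to a higher number in this assay is therefore expected: a 2.6-fold higher number from compound 3 to compound 4 (0.41 log units; beyond the scatter). For compound 4 the estimated value is 50000 nM, within an expected range of 18000 nM to 120000 nM.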

Compound 4, half-maximal inhibitory concentration: 5210 nM
Compound 4: middle estimate off by 9.6-fold (0.98 log units), on the high side; measured number below the stated range.
By their numbers in this assay, from the lowest: compounds 1, 4 and 2 (each within the scatter of the next, the first and the last beyond it); then compound 3.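

In this assay, exchanging 2,4-dimethoxyphenyl for 4-bromophenyl on the sulfonyl sulfur has no fixed direction, since the methyl-bearing compounds show a 3.7-fold lower number from compound 3 to compound 4 (0.57 log units; beyond the scatter), the opposite of the isopropyl-bearing pair: the same change on two cores in this assay, a 2.8-fold higher number (0.44 log units; beyond the scatter) from compound 1 to compound 2 and a 3.7-fold lower number (0.57 log units; beyond the scatter) from compound 3 to compound 4, 10-fold (1.02 log units) apart, beyond the scatter of two such steps Methyl in place of isopropyl also depends on its partner, as with 4-bromophenyl on the sulfonyl sulfur it gives only a 1.5-fold lower number from compound 2 to compound 4 (0.17 log units; within the scatter), far less than the step seen with 2,4-dimethoxyphenyl: the same change on two cores in this assay, a 7.1-fold higher number (0.85 log units; beyond the scatter) from compound 1 to compound 3 and a 1.5-fold lower number (0.17 log units; within the scatter) from compound 2 to compound 4, 10-fold (1.02 log units) apart, beyond the scatter of two such steps The two positions therefore cannot be judged separately, and the effect of one change cannot simply be added to that of the other.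

The compounds shown leave open how an ethyl chain, or a plain phenyl on the sulfonyl sulfur, would behave. Each comparison rests on one pair per core, and nothing here explains this dependence.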